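Replacing 3,4-dichlorophenyl with 2,3-dimethoxyphenyl on the shared core

The source may hold more compounds than are shown below. What is called first, only, known or untested is meant among the compounds shown, and "the series" means these compounds.

In a functional assay on HL-60 cells (Homo sapiens) for antiproliferative activity, with a stated time of 72 h (on this read-out lower numbers stand for stronger inhibition and higher numbers for weaker inhibition), compound 1 `Cc1ccc(CNc2ncnc3c2ncn3[C@@H]2O[C@H](CO)[C@@H](O)[C@H]2O)cc1` gives > 166000 nM as a limit of the assay and not as a number. In this assay, among the measured compounds shown here, compound 2 `OC[C@H]1O[C@@H](n2cnc3c(NCc4ccc(Cl)c(Cl)c4)ncnc32)[C@H](O)[C@@H]1O` gives 2000 nM as the only actual number so far. The next compound to be measured is compound 3 `COc1cccc(CNc2ncnc3c2ncn3[C@@H]2O[C@H](CO)[C@@H](O)[C@H]2O)c1OC` and its difference from compound 2 is 2,3-dimethoxyphenyl in place of 3,4-dichlorophenyl on a saturated chain carbon bound to a nitrogen on an aromatic ring with 2,3-dimethoxyphenyl in place of 3,4-dichlorophenyl on a saturated chain carbon bound to a nitrogen on an aromatic ring. For the measured compounds named here, one measured step bears on this change: an at least 83-fold lower number from compound 1 to compound 2 (1.91 log units; beyond the scatter) with 3,4-dichlorophenyl in place of 4-methylphenyl at the same place, a large step beyond the scatter. That step shows how far the number can move when this group changes, and compound 2 holds the better of the two results, so giving up 3,4-dichlorophenyl is expected to yield a higher number and weaker inhibition. The expected step is a 10-fold higher number from compound 2 to compound 3 (1.00 log units; beyond the scatter) and it is estimated to lie beyond the scatter, though probably to be smaller than the measured one. For compound 3 the estimate is 20000 nM with 4000 nM to 100000 nM as its expected range.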

Compound 3, half-maximal inhibitory concentration: > 166000 nM
Compound 3: no number, only a limit; the forecaster's own chance of this, stated with the estimate: 30%; at least 8.3-fold (0.91 log units) between middle value and limit.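

In this assay, moving from 3,4-dichlorophenyl to 2,3-dimethoxyphenyl on a saturated chain carbon bound to a nitrogen on an aromatic ring gives an at least 83-fold higher number from compound 2 to compound 3 (1.91 log units; beyond the scatter), so a second, quite different replacement of 3,4-dichlorophenyl also loses the measurable number. Compound 3 gives > 166000 nM, which is a limit of the assay and not a number, and the step between compound 1 and compound 3 cannot be read, as both rest on limits. Among the compounds shown, only the one carrying 3,4-dichlorophenyl gives an actual number, while the 4-methylphenyl and 2,3-dimethoxyphenyl compounds end at the same limit: the limit of > 166000 nM in this assay, at which 2 of the 3 values shown sit.

The compounds shown leave open how far compound 1 and compound 3 lie beyond that limit, and so whether either group differs from the other at all. They also leave open whether the number depends on the chlorine atoms themselves or on where the groups sit on the ring, a question that 4-chlorophenyl, 3-chlorophenyl or 3,4-dimethoxyphenyl at this place would bear on.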